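The compounds below may be only part of what the source reports. "The series", "measured", "known", "first", "only" and "open" are said of these compounds alone.

Of the compounds shown here, two with the same long unsaturated chain have been measured in an assay on isolated protein for inhibition of Fatty-acid amide hydrolase 1 (Homo sapiens); on this read-out lower numbers stand for stronger inhibition and higher numbers for weaker inhibition. Compound 1 `CCCCCCCC/C=C\CCCCCCC(=O)c1nnn(C)n1` gives 65 nM. Compound 2 `CCCCCCCC/C=C\CCCCCCC(=O)c1ncco1` gives 17 nM. For the measured compounds named here, the only measured step, a 3.8-fold lower number from compound 1 to compound 2 (0.58 log units; beyond the scatter), shows that exchanging one small aromatic ring for another on the carbonyl carbon changes the number moderately. On the numbers shown, compound 2 has the lowest value of the two, with compound 1 as its nearest neighbour.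

Compound 3 `CCCCCCCC/C=C\CCCCCCCC=O` differs from compound 2 by a larger change: formylmethyl in place of (1,3-oxazol-2-yl)carbonyl on a saturated chain carbon, six bonds along the chain from a double-bonded chain carbon. Going by the values given here, no measured step covers the loss of the whole ring together with its carbonyl, so the single step from compound 1 to compound 2 only hints that the ring matters. A weakening beyond the scatter is therefore expected, so that the step from compound 2 to compound 3 is estimated as a 24-fold higher number from compound 2 to compound 3 (1.37 log units; beyond the scatter). For compound 3 the expected value in this assay is 400 nM, within the range 100 nM to 2000 nM.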

Compound 3, inhibition constant: 190 nM
Compound 3: the middle estimate sits 2.1-fold (0.32 log units) above what was measured; the range from low to high includes it.
By their numbers in this assay, from the lowest: compound 2; then compound 1; then compound 3.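

In this assay, formylmethyl in place of (1,3-oxazol-2-yl)carbonyl gives an 11-fold higher number from compound 2 to compound 3 (1.05 log units; beyond the scatter), a step clearly larger than the one seen on exchanging one ring for the other. The other ring compound shows the same direction, with a 2.9-fold higher number from compound 1 to compound 3 (0.47 log units; beyond the scatter), so on these three compounds both ring-bearing groups give lower numbers than formylmethyl. No measurement at hand explains this difference.

From the compounds shown here alone, the ring and its carbonyl leave together in this change, so the share of each in the step remains open. A phenyl ring on the same carbonyl carbon, a carboxylic acid in the same place, or a shorter chain could help to separate these contributions and show how far the trend holds.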